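A few compounds are considered here, and "the series" means these few. Any claim that something is new, unique, unknown or untested is made for them only; others in the source may bear on it.

The series keeps one core and varies only the chain on the ring nitrogen. Compound 1 `NNC(=O)CN1C(=O)c2ccccc2NC1c1ccccc1` carries an aminocarbamoyl group on a saturated chain carbon bound to an amide-type nitrogen in a ring; in an assay on mitochondria for inhibition of Amine oxidase [flavin-containing] A (Bos taurus), read by fluorescence, with a stated time of 60 min (on this read-out lower numbers stand for stronger inhibition and higher numbers for weaker inhibition), compound 1 gives 38 nM. Compound 2 `COC(=O)CCN1C(=O)c2ccccc2NC1c1ccccc1` carries a (methoxycarbonyl)methyl group at that place, and in this assay compound 2 gives 92 nM. Compound 3 `NNC(=O)CCN1C(=O)c2ccccc2NC1c1ccccc1` carries an (aminocarbamoyl)methyl group there, and in this assay compound 3 gives 16 nM, the lowest number of the three, with its steps to both others beyond the scatter. The steps read a 2.4-fold higher number from compound 1 to compound 2 (0.38 log units; beyond the scatter), a 2.4-fold lower number from compound 1 to compound 3 (0.38 log units; beyond the scatter) and a 5.8-fold lower number from compound 2 to compound 3 (0.76 log units; beyond the scatter): the aminocarbamoyl chains beat the methoxycarbonyl one, and the longer aminocarbamoyl chain beats the shorter.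

Compound 4 `NNC(=O)CCCN1C(=O)c2ccccc2NC1c1ccccc1` lengthens the chain once more: (aminocarbamoyl)methyl in place of aminocarbamoyl on a saturated chain carbon, two bonds along the chain from an amide-type nitrogen in a ring. Within the data shown here, the only measured step that bears on this is a 2.4-fold lower number from compound 1 to compound 3 (0.38 log units; beyond the scatter), the same lengthening made one bond closer to the ring, which gave a modest gain. One step cannot settle whether a second lengthening gains again or the trend turns, so the expected step in this assay is a 1.1-fold lower number from compound 3 to compound 4 (0.06 log units; within the scatter). Compound 4 is estimated at 14 nM, within a range of 5 nM to 45 nM.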

Compound 4, half-maximal inhibitory concentration: 47 nM
The estimate for compound 4 lay 3.4-fold (0.53 log units) below the measured number; the measured number lies above the stated range.
By their numbers in this assay, from the lowest: compound 3; then compounds 1, 4 and 2 (each within the scatter of the next, the first and the last beyond it).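

Along the aminocarbamoyl chains the earlier gain in this assay does not continue: the further lengthening at this place, on a saturated chain carbon, two bonds along the chain from an amide-type nitrogen in a ring, reverses the direction (a 2.9-fold higher number from compound 3 to compound 4 (0.47 log units; beyond the scatter)), which leaves compound 3 with the lowest number of the series and its steps to all others beyond the scatter. The 3-(aminocarbamoyl)propyl chain of compound 4 also loses the separation from the other two compounds, with a 1.2-fold higher number from compound 1 to compound 4 (0.09 log units; within the scatter) and a 2.0-fold lower number from compound 2 to compound 4 (0.29 log units; within the scatter), so compound 4 cannot be told apart from either compound 1 or compound 2 and the earlier reading that aminocarbamoyl chains beat the methoxycarbonyl one does not hold for compound 4. Nothing at hand accounts for this turn at the position.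

On these data alone, whether a still longer chain carrying the aminocarbamoyl end stays level with compound 4 or moves further from compound 3 remains open. Also open, as far as these compounds go, is how far the result depends on the aminocarbamoyl end itself, as a carboxylic acid or a primary amide on the chain of compound 3 would show, and the methoxycarbonyl end is seen at one chain length only.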